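Hydroxy to methoxy on compound 1

The source may report more compounds than this note shows. Statements on the series, on what has been measured and on what is new or still open speak of the compounds shown alone.

compound 1 `COc1ccc2c(=O)cc(/C=C/[S+](C)[O-])oc2c1O` gives > 10000 nM
compound 2 `C[S+]([O-])/C=C/c1cc(=O)c2ccccc2o1` gives 9000 nM

In an ADME assay on WS1 cells (Homo sapiens) for inhibition, with a stated time of 48 h (on this read-out lower numbers stand for stronger inhibition and higher numbers for weaker inhibition), compound 1 stands at > 10000 nM as a limit of the assay and not a number. Neither compound has yet shown strong inhibition on this read-out, and compound 2 supplies the only actual number.

Compound 3 `COc1ccc2c(=O)cc(/C=C/[S+](C)[O-])oc2c1OC` keeps the core of compound 1 and differs from it in one place. It goes from hydroxy to methoxy, with methyl in place of hydrogen on an oxygen on an aromatic ring as the whole change.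

Within the data shown here, no two measured compounds differ in one place, so no measured step gives a size for this change. Among the measured compounds shown here, the one number to go on is compound 2 at 9000 nM in weak territory. A shift beyond the scatter is not expected, and the expected step of a number no higher from compound 1 to compound 3 (the limit leaves the size open) has no firm direction. In this assay compound 3 is estimated at 10000 nM with an expected range from 4000 nM to 30000 nM and a good chance of ending up only as a limit.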

Compound 3, half-maximal inhibitory concentration: > 10000 nM
Compound 3: a limit, no number; the forecaster's own chance of this, stated with the estimate: 60%; the middle value sits exactly at the limit.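

No step can be read from compound 1 to compound 3, because the values of both compounds are limits of the assay and not numbers: the limit of > 10000 nM in this assay, at which 2 of the 3 values shown sit.

The compounds shown leave open whether methyl in place of hydrogen on an oxygen on an aromatic ring changes inhibition in this assay at all, and where compound 1 and compound 3 actually lie.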